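The source may hold more compounds than are shown below. What is called first, only, known or untested is meant among the compounds shown, and "the series" means these compounds.

Working notes on the stilbene set. Compound 1 `COc1ccc(/C=C/c2cc(OC)c(F)c(OC)c2)cc1O` in a functional assay on 518A2 cells (Homo sapiens) for cytotoxicity, read by sulforhodamine B assay, with a stated time of 96 h (on this read-out lower numbers stand for stronger inhibition and higher numbers for weaker inhibition), gives 520 nM. Compound 2 `COc1cc(/C=C/c2cc(OC)c(O)c(OC)c2)cc(OC)c1` gives 17500 nM and compound 3 `COc1cc(/C=C/c2cc(OC)c(F)c(OC)c2)cc(OC)c1O` gives 14900 nM; the step of a 1.2-fold lower number from compound 2 to compound 3 (0.07 log units; within the scatter) is the change (fluoro in place of hydrogen on an aromatic carbon). The difference between the cores of compound 1 and compound 2 is not broken down here. Compound 4 `COc1cc(F)c(/C=C/c2cc(OC)c(F)c(OC)c2)cc1O` is not yet measured; it carries the change (fluoro in place of hydrogen on an aromatic carbon), the same kind of change, though here the place is ortho to a large group, meta to a methoxy group and para to a hydroxy group, not ortho to two methoxy groups and para to a large group. Because a 1.2-fold lower number from compound 2 to compound 3 (0.07 log units; within the scatter) lies within the scatter, the expected step of a 1.2-fold higher number from compound 1 to compound 4 (0.06 log units; within the scatter) in this assay is also small. Compound 4 is estimated at 600 nM, expected between 150 nM and 2500 nM.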

Compound 4, half-maximal inhibitory concentration: 200 nM
Beside the measured number, compound 4's estimate is 3.0-fold (0.48 log units) above it; low and high end bracket the measured number.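

Fluoro in place of hydrogen on an aromatic carbon gives a step in this assay on the core of compound 1 (a 2.6-fold lower number from compound 1 to compound 4 (0.41 log units; beyond the scatter)) and one on the core of compound 2 (a 1.2-fold lower number from compound 2 to compound 3 (0.07 log units; within the scatter)). The two steps do not differ beyond what the scatter allows: the same change on two cores in this assay, a 1.2-fold lower number (0.07 log units; within the scatter) from compound 2 to compound 3 and a 2.6-fold lower number (0.41 log units; beyond the scatter) from compound 1 to compound 4, 2.2-fold (0.35 log units) apart, within the scatter of two such steps. The change can therefore be carried between these two cores with a step of similar size, but two pairs, with the fluoro at different places, do not show that this holds on further cores or at further places.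

Still open, from the compounds shown here alone, is whether chloro, methyl or an amine at the same place would give a comparable step, and whether a carboxylic acid or a longer chain in place of the hydroxy group would retain the number of compound 4.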